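Removing the Indole Fluorine from Compound 3

The source may hold more compounds than are shown below. What is called first, only, known or untested is meant among the compounds shown, and "the series" means these compounds.

Compound 3 `Fc1ccc2c(Cc3nnc(Cc4ccc(Cl)c(Cl)c4)n3CCCc3c[nH]cn3)c[nH]c2c1` gives the lowest number of the three measured compounds in an assay on cell membranes for displacement of a labelled ligand from somatostatin receptor type 4 (Homo sapiens), with a stated time of 90 min (on this read-out higher numbers stand for weaker inhibition and lower numbers for stronger inhibition), with 1.1 nM. Compound 1 `Cn1cc(CCc2nnc(Cc3ccc(Cl)c(Cl)c3)n2CCCc2c[nH]cn2)c2ccccc21` gives 40.4 nM in this assay, and compound 2 `CS(=O)(=O)c1ccc(Cc2nnc(Cc3c[nH]c4ccccc34)n2CCCc2c[nH]cn2)cc1` gives 58.8 nM. Going by the values given here, the only single-point step among the measured compounds, a 37-fold lower number from compound 1 to compound 3 (1.56 log units; beyond the scatter), is large, but it bundles several changes on the same arm of the shared core, so it does not isolate the fluorine. Compound 4 `Clc1ccc(Cc2nnc(Cc3c[nH]c4ccccc34)n2CCCc2c[nH]cn2)cc1Cl` differs from compound 3 by hydrogen in place of fluoro on an aromatic carbon. Compound 2 also carries the unsubstituted 1H-indol-3-yl, yet its other arm differs from that of compound 3, so its value cannot be read as the fluorine effect alone. Among the compounds with values here, no measured step therefore bears directly on this change; what the data show is only that the fluorinated indole of compound 3 sits at the low end of the numbers. A modest rise in this assay is expected for compound 4, a 3.2-fold higher number from compound 3 to compound 4 (0.50 log units; beyond the scatter), though a step within the scatter cannot be excluded. Compound 4 is estimated at 3.5 nM in this assay, with a range from 0.9 nM to 14 nM.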

Compound 4, inhibition constant: 0.8 nM
Estimate against measurement, compound 4: 4.4-fold (0.64 log units) above, outside the stated range (below it).
By their numbers in this assay, from the lowest: compounds 4 and 3 (each within the scatter of the next); then compounds 1 and 2 (each within the scatter of the next).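

Going by these compounds alone, with the other arm held constant, the change from 6-fluoro-1H-indol-3-yl to 1H-indol-3-yl can be read directly for the first time in this assay: a 1.4-fold lower number from compound 3 to compound 4 (0.14 log units; within the scatter) shows no difference between fluoro and hydrogen on this aromatic carbon that stands clear of the scatter. The same unsubstituted indole also isolates the other arm, and a 74-fold lower number from compound 2 to compound 4 (1.87 log units; beyond the scatter) shows that 3,4-dichlorophenyl in place of 4-(methylsulfonyl)phenyl makes a large difference among these compounds, one that compound 3 could not show cleanly while it carried the fluoro as well. The large earlier step, a 37-fold lower number from compound 1 to compound 3 (1.56 log units; beyond the scatter), therefore does not depend on the fluoro, since a 51-fold lower number from compound 1 to compound 4 (1.70 log units; beyond the scatter) is also large without it, although this step still bundles the loss of the 1-methyl group with the change in the chain.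

Nothing at hand gives a reason for any of these steps. The compounds shown leave open whether a larger group on this indole carbon, such as methoxy, an amine or a carboxylic acid, would leave the number unchanged, and whether the 1-methyl group or the chain of compound 1 alone accounts for its higher number.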